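Amine headgroup changes on a quinazoline anilide series

The source may hold more compounds than are shown below. What is called first, only, known or untested is meant among the compounds shown, and "the series" means these compounds.

Measured so far:
compound 1 `COc1cc2c(Nc3ccc(C#N)cc3)ncnc2cc1OCCCN(C)C` — 45000 nM
compound 2 `COc1cc2c(Nc3ccc(C#N)cc3)ncnc2cc1OCCCN1CCC(c2ccccc2)CC1` — 9800 nM

Compound 1 `COc1cc2c(Nc3ccc(C#N)cc3)ncnc2cc1OCCCN(C)C` and compound 2 `COc1cc2c(Nc3ccc(C#N)cc3)ncnc2cc1OCCCN1CCC(c2ccccc2)CC1` differ only in the amine at the end of the chain. In a functional assay on MCF7 cells (Homo sapiens) for antiproliferative activity, read by MTT assay, with a stated time of 72 h (on this read-out lower numbers stand for stronger inhibition and higher numbers for weaker inhibition), compound 1 gives 45000 nM and compound 2 gives 9800 nM. Within the data shown here, the one measured step, a 4.6-fold lower number from compound 1 to compound 2 (0.66 log units; beyond the scatter), is beyond the scatter. Among the measured compounds shown here, compound 2 therefore holds the lower of the two numbers seen so far, with compound 1 as its only neighbour.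

Compound 3 `COc1cc2c(Nc3ccc(C#N)cc3)ncnc2cc1OCCCN1CCc2ccccc2C1` has not been run yet. The change from compound 2 is 1,2,3,4-tetrahydroisoquinolin-2-yl in place of 4-phenylpiperidin-1-yl on a saturated chain carbon, three bonds along the chain from an oxygen on an aromatic ring. The aromatic ring is kept; the only shift is from a pendant ring on the saturated ring to a fused one. For the measured compounds named here, the single step that bears on this position runs from a small acyclic amine to a ring-bearing amine and is not a close analogue of a ring-to-ring swap, so it gives direction only loosely. With the aromatic ring retained, no step beyond the scatter in this assay is expected, and a 1.0-fold higher number from compound 2 to compound 3 (0.01 log units; within the scatter) is estimated to be small. Compound 3 is expected to give about 10000 nM, within a range of 4000 nM to 25000 nM.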

Compound 3, half-maximal inhibitory concentration: > 100000 nM
Compound 3: only a limit was reported (the forecaster's own chance of this, stated with the estimate: 5%); at least 10-fold (1.00 log units) between middle value and limit.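

In this assay compound 3 is reported only as a limit, not as a number: the limit of > 100000 nM in this assay, at which 1 of the 3 values shown sits. This position therefore responds to how the aromatic ring is attached to the amine, not merely to whether such a ring is present: 1,2,3,4-tetrahydroisoquinolin-2-yl in place of 4-phenylpiperidin-1-yl, with the same ring types on both sides, gives an at least 10-fold higher number from compound 2 to compound 3 (1.00 log units; beyond the scatter). The trend suggested by the first pair does not hold for ring-bearing amines in general, since compound 3 goes against it with an at least 2.2-fold higher number from compound 1 to compound 3 (0.34 log units; beyond the scatter), whereas only compound 2 improves on the small acyclic dimethylamino group.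

Going by these compounds, these three compounds cannot separate the effect of fusing the aromatic ring from that of the smaller headgroup, and the true size of both new steps stays open while compound 3 remains a limit. A plain piperidin-1-yl and a 4-benzylpiperidin-1-yl at the end of the same chain would show whether the lower number of compound 2 depends on the pendant phenyl group and on how far that ring sits from the nitrogen.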